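Bromo in Place of Ethyl on the Triazole Aryl Ring

The source may report more compounds than this note shows. Statements on the series, on what has been measured and on what is new or still open speak of the compounds shown alone.

Compound 1, `N#CC1=C(N)Oc2c(c3nc4ccccc4nc3c3ccccc23)C12C(=O)N(Cc1cnnn1-c1ccc([N+](=O)[O-])cc1)c1ccccc12`, in an ADME assay on L02 cells (Homo sapiens) for antiproliferative activity, read by MTT assay, with a stated time of 48 h (a lower number here means a stronger inhibitor, a higher number a weaker inhibitor), gives > 50000 nM.
Compound 2, `CCc1ccccc1-n1nncc1CN1C(=O)C2(C(C#N)=C(N)Oc3c(N)cc4nc5ccccc5nc4c32)c2ccccc21`, in this assay gives 22900 nM.

Compound 2 holds the only plain number shown here. The value of compound 1 is a limit of the assay and not a number, namely (the limit of > 50000 nM in this assay, at which 1 of the 2 values shown sits). Compound 3, `N#CC1=C(N)Oc2c(N)cc3nc4ccccc4nc3c2C12C(=O)N(Cc1cnnn1-c1ccccc1Br)c1ccccc12`, differs from compound 2 in one place: bromo in place of ethyl on an aromatic carbon. Within the data shown here, no step between two measured compounds covers this change, so nothing measured tells its size, and a step of no more than the usual scatter, in no particular direction, is expected, roughly a 1.1-fold higher number from compound 2 to compound 3 (0.04 log units; within the scatter). On that footing compound 3 is expected to give about 25000 nM in this assay. The expected range for compound 3 runs from 10000 nM to 60000 nM, with some chance that the assay reports only a limit.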

Compound 3, half-maximal inhibitory concentration: 29200 nM
Compound 3: middle estimate off by 1.2-fold (0.07 log units), on the low side; the measured number falls inside the stated range.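

Read in this assay, the change from 2-ethylphenyl to 2-bromophenyl gives the first measured step at this position: a 1.3-fold higher number from compound 2 to compound 3 (0.11 log units; within the scatter). Bromo, with one heavy atom, thus stands in for ethyl, with two, on an aromatic carbon ortho to a large group, and the two compounds cannot be told apart in this read-out. Nothing at hand offers a reason for how closely compound 2 and compound 3 agree.

The compounds shown leave open how this same place would respond to a group of another kind, such as an amine, a carboxylic acid or a longer chain. They also leave open whether bromo and ethyl would still read alike on a different carbon of that aromatic ring.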